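The compounds below may be only part of what the source reports. "The series", "measured", "known", "first", "only" and "open" are said of these compounds alone.

Measured compounds in the series:

compound 1, `CN(C)CCn1cnnc1-c1cc(Oc2ccc(NC(=O)N/N=C/c3ccc(Cl)cc3Cl)cc2F)ccn1`: 4760 nM
compound 2, `COc1ccc(OC)c(/C=N/NC(=O)Nc2ccc(Oc3ccnc(-c4nncn4CCN(C)C)c3)c(F)c2)c1`: "not determined" (no result reported)
compound 3, `CN(C)CCn1cnnc1-c1cc(Oc2ccc(NC(=O)N/N=C/c3ccc(O)c(Br)c3)cc2F)ccn1`: 5560 nM

All three share the same core and differ only in the aryl group on the carbon with a double bond to nitrogen. In an ADME assay on WI-38 cells (Homo sapiens) for cytotoxicity, read by MTT assay, with a stated time of 72 h (a lower number here means a stronger inhibitor, a higher number a weaker inhibitor), compound 3 gives 5560 nM, the highest of the two numbers available, with compound 1 nearest at 4760 nM; the step of a 1.2-fold higher number from compound 1 to compound 3 (0.07 log units; within the scatter) is within the scatter, so the two cannot be ordered. Compound 2 carries no result in this assay.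

Compound 4, `CN(C)CCn1cnnc1-c1cc(Oc2ccc(NC(=O)N/N=C/c3ccccc3O[N+](=O)[O-])cc2F)ccn1`, has not yet been measured in this assay. It differs from compound 3 by 2-(nitrooxy)phenyl in place of 3-bromo-4-hydroxyphenyl on a carbon with a double bond to nitrogen. Within the data shown here, the only measured step that bears on this position is the one from compound 1 to compound 3, which exchanged one aryl group for another without moving the number beyond the scatter. On that basis a further aryl exchange at the same carbon is expected to leave the number about where it stands, with no directional shift beyond the scatter, the expected step being a 1.1-fold lower number from compound 3 to compound 4 (0.05 log units; within the scatter). The estimate for compound 4 in this assay is therefore 5000 nM, with a range from 2400 nM to 11000 nM.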

Compound 4, half-maximal inhibitory concentration: 6860 nM
Compound 4: the middle estimate sits 1.4-fold (0.14 log units) below what was measured; the range from low to high includes it.
By their numbers in this assay, from the lowest: compounds 1, 3 and 4 (each within the scatter of the next).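

At the carbon with a double bond to nitrogen, 2-(nitrooxy)phenyl gives a 1.2-fold higher number from compound 3 to compound 4 (0.09 log units; within the scatter) in this assay and a 1.4-fold higher number from compound 1 to compound 4 (0.16 log units; within the scatter), so neither exchange moves the number beyond the scatter. This extends the earlier picture to an aryl group with 0 hydrogen-bond donors and 3 hydrogen-bond acceptors, against 1 of each in 3-bromo-4-hydroxyphenyl, and compounds 1, 3 and 4 still cannot be separated at this position. Nothing at hand bears on why the number stays within the scatter across these three groups.

Going by these compounds, all the groups compared here are substituted phenyl rings, so the effect of a phenyl ring carrying an amine or a carboxylic acid remains open. Also open, on these data alone, is whether a simple alkyl chain in place of the ring would leave the number within the scatter.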